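Swapping the para substituent: from methoxy to tert-butyl

The source may report more compounds than this note shows. Statements on the series, on what has been measured and on what is new or still open speak of the compounds shown alone.

Measured compounds, in an assay on isolated protein for inhibition of protein deacetylase HDAC6 (Homo sapiens), read by fluorescence, with stated times of 10 min and 2 h; on this read-out lower numbers stand for stronger inhibition and higher numbers for weaker inhibition:
- Compound 1, `O=C(NO)c1ccc(CN2C(=O)CN(Cc3ccc(Cl)cc3)C2=O)cc1`: compound 1 gives 8.3 nM.
- Compound 2, `Cc1ccc(CN2CC(=O)N(Cc3ccc(C(=O)NO)cc3)C2=O)cc1`: compound 2 gives 17.6 nM.
- Compound 3, `COc1ccc(CN2CC(=O)N(Cc3ccc(C(=O)NO)cc3)C2=O)cc1`: compound 3 gives 28.2 nM.

Three compounds share one core and differ only in the group on the outer aromatic ring. Compound 3 has the highest number of the three. Its nearest neighbour is compound 2, and the gap a 1.6-fold higher number from compound 2 to compound 3 (0.20 log units; within the scatter) lies within the scatter, so the two cannot be ordered. Its furthest neighbour is compound 1, and the step of a 3.4-fold higher number from compound 1 to compound 3 (0.53 log units; beyond the scatter) lies beyond the scatter.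

Compound 4, `CC(C)(C)c1ccc(CN2CC(=O)N(Cc3ccc(C(=O)NO)cc3)C2=O)cc1`, is the next member: tert-butyl in place of methoxy on an aromatic carbon. Among the measured compounds shown here, no measured step puts a tert-butyl in that place, so the expectation rests on the three known steps: a 2.1-fold higher number from compound 1 to compound 2 (0.33 log units; beyond the scatter), a 3.4-fold higher number from compound 1 to compound 3 (0.53 log units; beyond the scatter) and a 1.6-fold higher number from compound 2 to compound 3 (0.20 log units; within the scatter). All three are modest or within the scatter, which suggests that exchanging one small group for another at this position moves this assay only a little.

Compound 4 is therefore expected to land near compound 3, with an estimated step of a 1.1-fold higher number from compound 3 to compound 4 (0.03 log units; within the scatter), more likely within the scatter than beyond it. The estimate for compound 4 in this assay is 30 nM, with a range from 10 nM to 90 nM.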

Compound 4, half-maximal inhibitory concentration: 40.7 nM
The estimate for compound 4 lay 1.4-fold (0.13 log units) below the measured number; measured number inside the range.
By their numbers in this assay, from the lowest: compound 1; then compounds 2, 3 and 4 (each within the scatter of the next, the first and the last beyond it).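

In this assay the position accepts a clear increase in size: tert-butyl brings 4 heavy atoms where methoxy has 2, yet a 1.4-fold higher number from compound 3 to compound 4 (0.16 log units; within the scatter) stays within the scatter, so these two compounds cannot be ordered. The wider comparisons are more informative. They show a small but real cost across the series: a 2.3-fold higher number from compound 2 to compound 4 (0.36 log units; beyond the scatter) and a 4.9-fold higher number from compound 1 to compound 4 (0.69 log units; beyond the scatter) both lie beyond the scatter, and both are still only modest, so even the widest gap among these four groups leaves compound 4 a nanomolar inhibitor. Nothing measured here explains why chloro sits at the low end of this series and tert-butyl at the high end, or why the steps stay so small.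

On these data alone, what remains open is whether this tolerance holds only for groups like these or extends to a different kind of group at this place, such as an amine, a carboxylic acid or a longer chain. A second ring attached here, such as a phenyl group, would test the limit of size further than tert-butyl does.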